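The source may hold more compounds than are shown below. What is called first, only, known or untested is meant among the compounds shown, and "the series" means these compounds.

Measured so far in a physicochemical assay for pharmacokinetics; a lower number here means that the compound disappears faster, a higher number that the compound lasts longer:
- compound 1 `COc1cccc(CNC(=O)N2C(=O)c3ccccc3S2(=O)=O)c1`: 0.523 h
- compound 2 `O=C(NCc1ccc(C(F)(F)F)cc1)N1C(=O)c2ccccc2S1(=O)=O`: 0.212 h
- compound 3 `O=C(NCc1ccccc1)N1C(=O)c2ccccc2S1(=O)=O`: 1.02 h

Compound 3 stands level with compound 1 within the scatter, and clear of compound 2 with a 4.8-fold higher number from compound 2 to compound 3 (0.68 log units; beyond the scatter). Compound 4 `COc1ccccc1CNC(=O)N1C(=O)c2ccccc2S1(=O)=O` has methoxy in place of hydrogen on an aromatic carbon, ortho to a large group: methoxy in place of hydrogen on an aromatic carbon. Going by the values given here, no measured compound carries a group at this place. The nearest guide is the methoxy step, a 2.0-fold higher number from compound 1 to compound 3 (0.29 log units; within the scatter), while the trifluoromethyl step involves a different group. A small drop in this assay is therefore expected, at most slightly beyond the scatter. The expected step is a 1.6-fold lower number from compound 3 to compound 4 (0.20 log units; within the scatter). The estimate for compound 4 is 0.65 h, with an expected range of 0.3 h to 1.3 h.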

Compound 4, half-life: 1.12 h
The estimate for compound 4 lay 1.7-fold (0.24 log units) below the measured number, and the stated range covers the measured number.
By their numbers in this assay, from the lowest: compound 2; then compounds 1, 3 and 4 (each within the scatter of the next, the first and the last beyond it).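

In this assay, methoxy on an aromatic carbon ortho to a large group stands level with hydrogen, with a 1.1-fold higher number from compound 3 to compound 4 (0.04 log units; within the scatter), so this place accepts that group without a step beyond the scatter. The 2-methoxyphenyl in place of 3-methoxyphenyl change gives a 2.1-fold higher number from compound 1 to compound 4 (0.33 log units; beyond the scatter), so where methoxy sits on the ring counts modestly in this pair. Nothing available bears on the reason for either step.

Open, going by these compounds, is how an amine or a carboxylic acid would read at this place. Also open, on these data alone, is whether ethoxy, a longer chain than methoxy, would stay level with hydrogen there.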